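The compounds below may be only part of what the source reports. "The series", "measured", "known", "first", "only" and "open" are said of these compounds alone.

Measured in a functional assay on MCF7 cells (Homo sapiens) for cytotoxicity, read by MTT assay, with a stated time of 72 h; on this read-out lower numbers stand for stronger inhibition and higher numbers for weaker inhibition:
- compound 1 `COc1ccc(/C=C2\CCC/C(=C\c3ccc(Cl)cc3)C2=O)cc1OC`: 6300 nM
- compound 2 `COc1ccc(/C=C2\CCC/C(=C\c3cccc(O)c3)C2=O)cc1OC`: 2900 nM

Compound 2 has the lower of these two numbers, which makes it the stronger inhibitor of the pair. Compound 3 `COc1ccc(/C=C2\CCC/C(=C\c3ccc(Cl)cc3Cl)C2=O)cc1OC` has not yet been measured. It carries 2,4-dichlorophenyl in place of 3-hydroxyphenyl on a double-bonded chain carbon bound to a double-bonded ring carbon.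

For the measured compounds named here, only one measured step bears on this change: a 2.2-fold lower number from compound 1 to compound 2 (0.34 log units; beyond the scatter). That modest step replaced 4-chlorophenyl with 3-hydroxyphenyl at the same place. The change to compound 3 again removes 3-hydroxyphenyl and brings back a chlorine-bearing ring, so a step of similar size toward a higher number seems likely. Going by the values given here, no measured compound carries 2,4-dichlorophenyl, so the range stays wide. The expected step is a 1.7-fold higher number from compound 2 to compound 3 (0.24 log units; within the scatter). The estimated value for compound 3 is 5000 nM, with an expected range of 1800 nM to 14000 nM.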

Compound 3, half-maximal inhibitory concentration: 16200 nM
Compound 3: middle estimate off by 3.2-fold (0.51 log units), on the low side, outside the stated range (above it).
By their numbers in this assay, from the lowest: compound 2; then compound 1; then compound 3.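

In this assay, chloro in place of hydrogen on an aromatic carbon gives a 2.6-fold higher number from compound 1 to compound 3 (0.41 log units; beyond the scatter), so a second chlorine on this ring moves the number further up rather than leaving it unchanged. The wider change gives a 5.6-fold higher number from compound 2 to compound 3 (0.75 log units; beyond the scatter), which shows that this place on a double-bonded chain carbon responds more strongly to the choice of ring than the first pair alone revealed, and among these three compounds, the ring with the hydroxyl, 3-hydroxyphenyl, gives the lowest number. No available evidence explains why these ring changes shift the number.

The compounds shown leave open whether the hydroxyl group itself accounts for the lower number of compound 2. A ring carrying an amine or a carboxylic acid at this place could help to test how far that pattern extends.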